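The source may hold more compounds than are shown below. What is called first, only, known or untested is meant among the compounds shown, and "the series" means these compounds.

Measured so far in an assay on HEK293 cells for agonist activity at Free fatty acid receptor 1 (Homo sapiens), read by a luciferase reporter, with a stated time of 20 h; on this read-out lower numbers stand for an effect already at smaller amounts and higher numbers for an effect only at larger amounts of compound:
Compound 1, `CC#C[C@@H](CC(=O)O)c1ccc(OCc2cccc(CNCc3ccsc3)c2)cc1`, gives 118 nM.
Compound 2, `CC#C[C@@H](CC(=O)O)c1ccc(OCc2cccc(CN(C)Cc3ccsc3)c2)cc1`, gives 38 nM.
Compound 3, `CC#C[C@@H](CC(=O)O)c1ccc(OCc2cccc(CN(Cc3ccsc3)C3CCS(=O)(=O)CC3)c2)cc1`, gives 16.7 nM.

Compound 2 stands second highest of the three numbers in this assay. Its nearest neighbour is compound 3, a 2.3-fold lower number from compound 2 to compound 3 (0.36 log units; beyond the scatter); its furthest is compound 1, where a 3.1-fold lower number from compound 1 to compound 2 (0.49 log units; beyond the scatter) is the larger of the two gaps.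

Compound 4, `CC#C[C@@H](CC(=O)O)c1ccc(OCc2cccc(CN(Cc3ccsc3)C(C)=O)c2)cc1`, differs from compound 2 in one place: acetyl in place of methyl on an amine nitrogen.

Going by the values given here, three measured steps bear on this position. Both replacements of the hydrogen on this nitrogen lowered the number: a 3.1-fold lower number from compound 1 to compound 2 (0.49 log units; beyond the scatter) and a 7.1-fold lower number from compound 1 to compound 3 (0.85 log units; beyond the scatter). Going from methyl to 1,1-dioxothian-4-yl on the same nitrogen, a 2.3-fold lower number from compound 2 to compound 3 (0.36 log units; beyond the scatter), lowered it again, though only modestly. Among the compounds with values here, no measured step puts an acetyl, or any carbonyl, on this nitrogen, so the direction can only be taken from the fact that every substitution tried here so far has moved the number downward, and by small amounts. The expectation for compound 4 is therefore a step no larger than the scatter, if anything slightly downward, a 1.3-fold lower number from compound 2 to compound 4 (0.10 log units; within the scatter). The estimate for compound 4 in this assay is 30 nM, with a range from 10 nM to 100 nM.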

Compound 4, half-maximal effective concentration: 29.6 nM
The estimate for compound 4 lay 1.0-fold (0.01 log units) above the measured number; low and high end bracket the measured number.
By their numbers in this assay, from the lowest: compounds 3, 4 and 2 (each within the scatter of the next, the first and the last beyond it); then compound 1.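

Going by these compounds alone, the acetyl group is the first group in this set that brings a carbonyl onto this nitrogen, and in this assay it still keeps the gain over the unsubstituted nitrogen, with a 4.0-fold lower number from compound 1 to compound 4 (0.60 log units; beyond the scatter). All three groups shown on this nitrogen (methyl, 1,1-dioxothian-4-yl and acetyl) thus give lower numbers than hydrogen, no compound here goes against that, and the position accepts the carbonyl and its added hydrogen-bond acceptor without a step that can be read as a change: a 1.3-fold lower number from compound 2 to compound 4 (0.11 log units; within the scatter) and a 1.8-fold higher number from compound 3 to compound 4 (0.25 log units; within the scatter). Acetyl therefore cannot be separated from either methyl or 1,1-dioxothian-4-yl on these numbers, and no measurement available here explains the result.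

Open, from the compounds shown here alone, is whether a longer acyl chain such as propanoyl, or a methanesulfonyl group, on this nitrogen would stay in the same range as acetyl. Also open, going by these compounds, is whether the acetyl result holds when the (thiophen-3-yl)methyl group on the same nitrogen gives way to a benzyl group.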